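Swapping the Side Chain on the Amine Nitrogen of Compound 3

The source may hold more compounds than are shown below. What is called first, only, known or untested is meant among the compounds shown, and "the series" means these compounds.

Measured so far:
compound 1 `N#CC1=C(NCC(=O)O)N(c2ccccc2)C(=O)N2CCCCC(N3CCCC3)C12`: 81.7%
compound 2 `N#CC1=C(/N=C/Nc2ccc([N+](=O)[O-])cc2)N(c2ccccc2)C(=O)N2CCCCC(N3CCCC3)C12`: 41.5%
compound 3 `N#CC1=C(NCC(=O)N2CCCC2)N(c2ccccc2)C(=O)N2CCCCC(N3CCCC3)C12`: 49.8%

All three share one core and differ only in the group attached to a double-bonded ring carbon. In a functional assay on the whole organism (strain albino) for inhibition, with Rattus norvegicus as the target, read by paw edema, with stated times of 1 h and 2 h, at a dose of 20 mmol/kg by the intraperitoneal route (a lower number here means less inhibition, a higher number more inhibition at the dose given (going by the name of the read-out)), compound 1 gives 81.7%, the highest of the three. Compound 3 stands second with 49.8%, within the scatter of compound 2 at 41.5%. Beyond the scatter lies the step of a number 31.9 percentage points lower from compound 1 to compound 3 (beyond the scatter).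

Compound 4 `CCOC(=O)C(=O)NC1=C(C#N)C2C(N3CCCC3)CCCCN2C(=O)N1c1ccccc1` has not yet been measured. It differs from compound 3 by (ethoxycarbonyl)carbonyl in place of ((pyrrolidin-1-yl)carbonyl)methyl on an amine nitrogen. For the measured compounds named here, two measured steps bear on this. a number 31.9 percentage points lower from compound 1 to compound 3 (beyond the scatter) shows that replacing the hydroxy group on the carbonyl carbon of compound 1 costs a large amount, and a number 40.2 percentage points lower from compound 1 to compound 2 (beyond the scatter) shows that a larger replacement on the same ring carbon costs even more, while a number 8.3 percentage points higher from compound 2 to compound 3 (within the scatter) lies within the scatter. Compound 4, like compound 2 and compound 3, lacks the hydroxy group of compound 1, so it is expected to sit near those two rather than near compound 1, with a number 2.8 percentage points lower from compound 3 to compound 4 (within the scatter) expected to stay within the scatter. The estimate for compound 4 is 47%, with a range from 30% to 65%.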

Compound 4, a percentage reported as inhibition, in the whole organism at one dose (the size of the read-out at that dose, not a potency): 83.6%
Beside the measured number, compound 4's estimate is 36.6 percentage points below it; measured number above the stated range.
By their numbers in this assay, from the lowest: compounds 2 and 3 (each within the scatter of the next); then compounds 1 and 4 (each within the scatter of the next).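

In this assay, for the compounds shown here, the earlier compounds left open the reading that only the carboxymethyl group of compound 1 could give a high number at this position. The (ethoxycarbonyl)carbonyl group overturns that reading, with a number 33.8 percentage points higher from compound 3 to compound 4 (beyond the scatter) and a number 42.1 percentage points higher from compound 2 to compound 4 (beyond the scatter), while a number 1.9 percentage points higher from compound 1 to compound 4 (within the scatter) puts the two side chains on a par, so a chain with no hydroxy group can match carboxymethyl on this amine nitrogen. Nothing given here explains why this change has so large an effect.

As far as these compounds go, it remains open whether the ethyl ester or the carbonyl attached directly to the amine nitrogen carries the effect. An acetyl group, an oxalic acid half with a free carboxylic acid, or a longer propyl ester at the same place would help to separate these.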